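Swapping the Amine Substituent on an Aryl Sulfamate Core

The source may report more compounds than this note shows. Statements on the series, on what has been measured and on what is new or still open speak of the compounds shown alone.

Measured compounds:
compound 1, `NS(=O)(=O)Oc1ccc2c(c1)CN(C(=O)c1cccc(N(Cc3ccccc3)Cc3ccco3)c1)CC2`, 27.5%
compound 2, `CCCN(CCC)c1cccc(C(=O)N2CCc3ccc(OS(N)(=O)=O)cc3C2)c1`, 8.3%
compound 3, `CN(CCN1CCCCC1)c1cccc(C(=O)N2CCc3ccc(OS(N)(=O)=O)cc3C2)c1`, 24.5%

All three share the same core and differ only in the amine group on the aromatic carbon. In an assay on HEK293 cells for inhibition of Steryl-sulfatase (Homo sapiens), tested at 0.1 uM (a higher number here means a stronger effect of the compound at the concentration tested, a lower number a weaker effect), compound 3 gives 24.5%, the second highest of the three numbers. Its nearest neighbour is compound 1, whose value lies within the usual scatter of it, while compound 2 sits clearly lower, as the step of a number 16.2 percentage points higher from compound 2 to compound 3 (beyond the scatter) shows.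

Compound 4, `CCCN(Cc1ccccc1)c1cccc(C(=O)N2CCc3ccc(OS(N)(=O)=O)cc3C2)c1`, has not yet been measured. It differs from compound 3 in one place: benzyl(propyl)amino in place of methyl(2-(piperidin-1-yl)ethyl)amino on an aromatic carbon.

For the measured compounds named here, the only measured step that bears on this change is the one from compound 2 to compound 3, which was modest and upward. Compound 4 keeps one propyl chain of compound 2 while adding a benzyl, a group also present in compound 1, and compound 1 shows a number close to compound 3. Taken together, these point to a value somewhere between compound 2 and compound 1, so a small downward step is expected, a number 6.5 percentage points lower from compound 3 to compound 4 (within the scatter), likely within the scatter. Compound 4 is therefore estimated at 18%, with a range from 5% to 32%.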

Compound 4, a percentage reported as inhibition, at one concentration (the size of the read-out at that concentration, not a potency): 23.1%
For compound 4 the middle estimate is 5.1 percentage points below the measured one; measured number inside the range.
By their numbers in this assay, from the lowest: compound 2; then compounds 4, 3 and 1 (each within the scatter of the next).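

In this assay the move to benzyl(propyl)amino gives a number 1.4 percentage points lower from compound 3 to compound 4 (within the scatter) and the swap of furan-2-yl for ethyl gives a number 4.4 percentage points lower from compound 1 to compound 4 (within the scatter), so this aromatic carbon carries three quite different amine groups at one level, whether the added ring is the six-membered non-aromatic ring of compound 3 or the aromatic ring of compound 4. Putting phenyl in place of ethyl on one chain of compound 2 gives a number 14.8 percentage points higher from compound 2 to compound 4 (beyond the scatter), which ties the gain over dipropylamino to that single swap, although compound 3 reaches the same level with no benzyl group and so goes against any rule that a benzyl group is required. Nothing measured here explains these numbers.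

Each number comes from a single tested concentration, so these compounds leave open whether those within the scatter of each other would also match in potency. They also leave open whether a carboxylic acid at the end of the chain, a morpholine ring or a plain primary amine on this aromatic carbon would hold this level of inhibition or move it.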